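Swapping chloro for methoxy on the pyrimidine aryl group

The source may hold more compounds than are shown below. What is called first, only, known or untested is meant among the compounds shown, and "the series" means these compounds.

Compound 1 `COc1ccc(-c2nc(SCC(=O)c3sc(-c4ccccc4)nc3C)nc(N)c2C#N)cc1` gives -4.6% in an assay on membranes from CHO cells for displacement of a labelled ligand from adenosine receptor A1 (Homo sapiens), read by scintillation counting, with a stated time of 60 min, tested at 1 uM; a higher number here means more inhibition at the concentration tested (going by the name of the read-out), a lower number less inhibition.
Compound 2 `COc1ccc(-c2nc(C)c(C(=O)CSc3nc(N)c(C#N)c(-c4ccc(Cl)cc4)n3)s2)cc1` gives 1.1% in this assay.
Compound 3 `Cc1nc(-c2ccccc2)sc1C(=O)CSc1nc(N)c(C#N)c(-c2ccc(Cl)cc2)n1` gives -23% in this assay.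

Compound 2 stands highest of the three numbers in this assay, though its gap to compound 1 lies within the scatter; only compound 3 sits clearly apart, the step of a number 24.1 percentage points lower from compound 2 to compound 3 (beyond the scatter) being beyond the scatter. The unmeasured compound 4 `COc1ccc(-c2nc(C)c(C(=O)CSc3nc(N)c(C#N)c(-c4ccc(OC)cc4)n3)s2)cc1` differs from compound 2 in one place: methoxy in place of chloro on an aromatic carbon. The step that bears most directly on this is the reverse change at the same position, a number 18.4 percentage points lower from compound 1 to compound 3 (beyond the scatter), where chloro in place of methoxy on the aromatic carbon lowered the read-out by a modest amount beyond the scatter. Read backwards, methoxy in place of chloro would be expected to raise the number by a similar modest margin. The step of a number 24.1 percentage points lower from compound 2 to compound 3 (beyond the scatter) concerns a different aromatic carbon and bears only indirectly. Compound 4 is therefore expected to show a modest rise, a number 10.9 percentage points higher from compound 2 to compound 4 (beyond the scatter), in this assay. The estimate for compound 4 is 12%, with a range from -8% to 30%.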

Compound 4, a percentage reported as inhibition, at one concentration (the size of the read-out at that concentration, not a potency): 9%
For compound 4 the middle estimate is 3 percentage points above the measured one; the range from low to high includes it.
By their numbers in this assay, from the lowest: compound 3; then compounds 1, 2 and 4 (each within the scatter of the next, the first and the last beyond it).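

On the core of compound 2, the 4-chlorophenyl to 4-methoxyphenyl change gives a number 7.9 percentage points higher from compound 2 to compound 4 (within the scatter) in this assay, so this swap does not clearly move the read-out here, although the same change separated compound 1 from compound 3 beyond the scatter. The two steps still do not differ by more than the scatter allows, so the results do not show that the core alters the effect of this change: the same change on two cores in this assay, a number 18.4 percentage points lower (beyond the scatter) from compound 1 to compound 3 and a number 7.9 percentage points lower (within the scatter) from compound 4 to compound 2, 10.5 percentage points apart, within the scatter of two such steps. Methoxy in place of hydrogen on the other aryl group gives a number 13.6 percentage points higher from compound 1 to compound 4 (beyond the scatter), and this change also agrees across the two cores: the same change on two cores in this assay, a number 24.1 percentage points lower (beyond the scatter) from compound 2 to compound 3 and a number 13.6 percentage points lower (beyond the scatter) from compound 4 to compound 1, 10.5 percentage points apart, within the scatter of two such steps.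

The compounds shown leave open whether an amine or a carboxylic acid in place of methoxy on this aromatic carbon would shift the number. Going by these compounds, whether a longer chain such as ethoxy would behave like methoxy also remains open.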